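The source may hold more compounds than are shown below. What is called first, only, known or untested is meant among the compounds shown, and "the series" means these compounds.

Values in a functional assay on HCT-116 cells (Homo sapiens) for inhibition, read by MTT assay, with a stated time of 72 h; on this read-out higher numbers stand for weaker inhibition and lower numbers for stronger inhibition:
compound 1 `COc1cc(Oc2cccc(Nc3ccccc3)c2)cc(OC)c1CNCc1ccc(C)cc1`: 13800 nM
compound 2 `COc1cc(Oc2cccc(Nc3ccccc3)c2)cc(OC)c1CN[C@H](C)c1ccccc1`: > 20000 nM, a limit and not a number
compound 3 `COc1ccc([C@@H](C)NCc2c(OC)cc(Oc3cccc(Nc4ccccc4)c3)c(OC)c2OC)cc1`: 2440 nM

Compound 2 has only a limit: the limit of > 20000 nM in this assay, at which 1 of the 3 values shown sits. The next compound is compound 4 `COc1cc(Oc2cccc(Nc3ccccc3)c2)cc(OC)c1CNC1CC1`, which differs from compound 2 as follows: cyclopropyl in place of 1-phenylethyl on an amine nitrogen. In words, cyclopropyl stands in place of 1-phenylethyl on an amine nitrogen.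

For the measured compounds named here, only one measured step falls at this nitrogen with the core unchanged: an at least 1.4-fold higher number from compound 1 to compound 2 (0.16 log units; that floor lies within the scatter). That step is a floor within the scatter, and it shows no effect of a definite size. It also involves no exchange of this kind, so it gives weak guidance for compound 4. Going by the values given here, compound 3 at 2440 nM differs from the others in more than one place and offers no single-change step. The nearest measured number on the same core is compound 1 at 13800 nM, and a value in that region is the working expectation. The direction can only be read against a limit, so a modest move to a lower number is expected, and a second limit reading remains possible. The expected step is an at least 1.6-fold lower number from compound 2 to compound 4 (0.22 log units; that floor lies within the scatter). For compound 4 the estimate is 12000 nM, with an expected range from 4500 nM to 20000 nM.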

Compound 4, half-maximal inhibitory concentration: > 20000 nM
Compound 4: a limit, no number; the forecaster's own chance of this, stated with the estimate: 35%; middle value at least 1.6-fold (0.22 log units) from the limit.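

In this assay compound 4 gives > 20000 nM, which is a limit and not a number. Cyclopropyl in place of 4-methylbenzyl on the amine nitrogen gives an at least 1.4-fold higher number from compound 1 to compound 4 (0.16 log units; that floor lies within the scatter), so this exchange shows no effect of a definite size, and the step between the two limits, from compound 2 to compound 4, cannot be read. New here is that a group without a six-membered aromatic ring on this nitrogen gives no number either, so the small cyclopropyl and the larger 1-phenylethyl both end at the same limit: the limit of > 20000 nM in this assay, at which 2 of the 4 values shown sit.

Compound 3 gives 2440 nM but differs from the other compounds in more than one place, so the shown compounds do not assign that value to any single change. Going by these compounds, whether a longer alkyl chain, a 2-hydroxyethyl group or a benzyl group carrying a methoxy substituent on this nitrogen gives a number in this assay stays open, and so does the size of any step at this position that would start from compound 2 or compound 4.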